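A few compounds are considered here, and "the series" means these few. Any claim that something is new, unique, unknown or untested is made for them only; others in the source may bear on it.

The measured compounds in an assay on cells for antagonist activity at transient receptor potential cation channel subfamily V member 1 (Homo sapiens), read by FLIPR and calcium flux, with a stated time of 6 min; on this read-out lower numbers stand for stronger inhibition and higher numbers for weaker inhibition:
compound 1 `CC(C(=O)NCc1ccc(C(C)(C)C)nc1OCc1ccc(F)cc1)c1ccc(NS(C)(=O)=O)c(F)c1`, 0.8 nM
compound 2 `CC(C(=O)NCc1ccc(C(C)(C)C)nc1SCc1ccccc1)c1ccc(NS(C)(=O)=O)c(F)c1`, 4 nM
compound 3 `CC(C(=O)NCc1ccc(C(C)(C)C)cc1N1CCN(c2ccccc2)CC1)c1ccc(NS(C)(=O)=O)c(F)c1`, 0.8 nM

Compound 3 stands level with compound 1 at the digits given, the two together holding the lowest numbers of the three, while compound 2 gives a higher number than either. Going by the values given here, the only single-point step among the measured compounds is a 5.0-fold higher number from compound 1 to compound 2 (0.70 log units; beyond the scatter).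

Compound 4 `CC(C(=O)NCc1ccc(C(C)(C)C)cc1OCC(C)(C)C)c1ccc(NS(C)(=O)=O)c(F)c1` has not yet been measured in this assay. It differs from compound 3 by neopentyloxy in place of 4-phenylpiperazin-1-yl on an aromatic carbon. Among the compounds with values here, no measured step concerns this position or this pair of groups; the step from compound 1 to compound 2 alters a different attachment on a different core, and it bears on compound 4 only in showing that an exchange of the large group on the core can shift the number beyond the scatter. No alkoxy group of this kind appears among the measured compounds. A modest loss is therefore expected, a 3.8-fold higher number from compound 3 to compound 4 (0.57 log units; beyond the scatter). Compound 4 is estimated at 3 nM, with a range from 0.8 nM to 12 nM.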

Compound 4, inhibition constant: 3.8 nM
For compound 4 the middle estimate is 1.3-fold (0.10 log units) below the measured one, and the stated range covers the measured number.
By their numbers in this assay, from the lowest: compounds 1 and 3 (each within the scatter of the next); then compounds 4 and 2 (each within the scatter of the next).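

In this assay, neopentyloxy in place of 4-phenylpiperazin-1-yl, on the aromatic carbon meta to a tert-butyl group, gives a 4.8-fold higher number from compound 3 to compound 4 (0.68 log units; beyond the scatter). This is the only reading of this position among the compounds shown, and it puts a number on an exchange that removes both rings and lowers the count of heavy atoms, with compound 4 still at 3.8 nM. No measurement given here accounts for the size of this step.

The compounds shown leave open whether the difference follows the terminal phenyl, the piperazine ring or the overall size of the group, which a plain piperazine, a morpholine or a shorter ethoxy group at this position would help to separate. As far as these compounds go, whether the linking oxygen of neopentyloxy matters also stays open, and a neopentyl group joined through carbon would bear on that.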